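The source may report more compounds than this note shows. Statements on the series, on what has been measured and on what is new or still open speak of the compounds shown alone.

The measured compounds:
Compound 1, `Cc1cc(C)cc(-c2c(C)nn(-c3nc(-c4ccc(Cl)c(Cl)c4)c(SC(C)C)s3)c2C(=O)O)c1`, gives 2700 nM in a functional assay on BJAB cells (Homo sapiens) for antiproliferative activity, with a stated time of 4 days; a higher number here means that more compound is needed for the effect, a lower number that less compound is needed.
Compound 2, `Cc1nn(-c2nc(-c3ccc(Cl)c(Cl)c3)c(SC(C)C)s2)c(C(=O)O)c1-c1ccccc1Cl`, gives 13100 nM in this assay.

Among the compounds with values here, compound 2 stands at the higher of the two numbers in this assay; its only neighbour is compound 1, and the step of a 4.9-fold higher number from compound 1 to compound 2 (0.69 log units; beyond the scatter) lies beyond the scatter. Compound 3, `COc1ccc(C)cc1-c1c(C)nn(-c2nc(-c3ccc(Cl)c(Cl)c3)c(SC(C)C)s2)c1C(=O)O`, is not yet measured in this assay. It differs from compound 2 in one place: 2-methoxy-5-methylphenyl in place of 2-chlorophenyl on an aromatic carbon. Within the data shown here, the only measured step that bears on this exchange is a 4.9-fold higher number from compound 1 to compound 2 (0.69 log units; beyond the scatter), which shows that replacing the aryl group at this carbon can shift the number beyond the scatter. The incoming 2-methoxy-5-methylphenyl resembles the 2-chlorophenyl of compound 2 in carrying a single substituent on one side of the ring and the 3,5-dimethylphenyl of compound 1 in carrying a methyl group, so a number somewhere between compound 1 and compound 2 seems the most reasonable expectation. The step of a 2.2-fold lower number from compound 2 to compound 3 (0.34 log units; beyond the scatter) is thus expected to be modest and toward a lower number. Compound 3 is estimated at 6000 nM in this assay, within a range from 2000 nM to 18000 nM.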

Compound 3, half-maximal effective concentration: 9500 nM
Compound 3: middle estimate off by 1.6-fold (0.20 log units), on the low side, within the range that was stated.
By their numbers in this assay, from the lowest: compound 1; then compounds 3 and 2 (each within the scatter of the next).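

In this assay, putting 2-methoxy-5-methylphenyl in place of 2-chlorophenyl on this aromatic carbon gives a 1.4-fold lower number from compound 2 to compound 3 (0.14 log units; within the scatter), so the two groups are not told apart here, although the incoming group adds a hydrogen-bond acceptor and a larger heavy-atom count. The same group in place of 3,5-dimethylphenyl gives a 3.5-fold higher number from compound 1 to compound 3 (0.55 log units; beyond the scatter), so compound 1 now stands apart from both other compounds, and among these three the lowest number goes with 3,5-dimethylphenyl, while 2-chlorophenyl and 2-methoxy-5-methylphenyl stand together. Nothing available explains why these aryl groups sort in this way.

The compounds shown leave open whether the lower number of compound 1 goes with its two methyl groups or with the lack of a substituent at the 2-position of the ring, a question that a plain phenyl or a 3,5-dichlorophenyl at this carbon would bear on. They also leave open whether this ranking of aryl groups would hold if the neighbouring carboxy group were replaced by an amide.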